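The source may hold more compounds than are shown below. What is called first, only, known or untested is meant among the compounds shown, and "the series" means these compounds.

Working notes on the series.

Compound 1, `O=c1[nH]c(=O)n(CCC(CO)CO)cc1-c1ccco1`, carries a furanyl group on the shared core. In a functional assay on HeLa cells (Homo sapiens) for antiproliferative activity, read by MTT assay, with a stated time of 72 h (a lower number here means a stronger inhibitor, a higher number a weaker inhibitor), compound 1 returns only a limit of the assay, > 100000 nM. Compound 2, `CCCCCCCCC#Cc1cn(CCC(CO)CO)c(=O)[nH]c1=O`, carries instead a decynyl chain on the same position of the core. In this assay compound 2 gives 58900 nM. Within the set compound 2 holds the only numerical value; the other entry is a limit, recorded as the limit of > 100000 nM in this assay, at which 1 of the 2 values shown sits. Among the compounds with values here, no step between two measured compounds is available here, so no measured size of change can be quoted; the two entries show only that compound 2 falls inside the measurable range while compound 1 does not.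

Compound 3, `O=c1[nH]c(=O)n(CCC(CO)CO)cc1C#CCCCCl`, is the next member to be measured in this assay. It differs from compound 2 by a single change: chloro in place of pentyl on a saturated chain carbon, three bonds along the chain from a triple-bonded carbon. The shortened, chlorine-terminated chain is expected to move the number upward, toward the limit seen for compound 1, by a step of a 1.5-fold higher number from compound 2 to compound 3 (0.18 log units; within the scatter). The estimate for compound 3 in this assay is therefore 90000 nM, with a range from 35000 nM to 250000 nM, and a fair chance that only a limit is reported.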

Compound 3, half-maximal inhibitory concentration: > 100000 nM
Compound 3 was reported as a limit (the forecaster's own chance of this, stated with the estimate: 45%); middle value at least 1.1-fold (0.04 log units) from the limit.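

In this assay, chloro in place of pentyl on a saturated chain carbon, three bonds along the chain from a triple-bonded carbon, gives an at least 1.6-fold higher number from compound 2 to compound 3 (0.22 log units; that floor lies within the scatter). Within the data shown here, this is the first step readable at this chain position, but it gives only a floor, and that floor does not establish a real loss of activity on its own; the true size of the step remains unknown. The step between compound 1 and compound 3 cannot be read, and the decynyl chain of compound 2 remains the only substituent on the shared core with a numerical value, the rest of the set resting at a limit: the limit of > 100000 nM in this assay, at which 2 of the 3 values shown sit.

The change shortens the chain and places chlorine at its end in a single step, so the compounds shown do not separate the contribution of chain length from that of the chloro group. Going by these compounds, a decynyl chain ending in chlorine, or a 5-carbon alkynyl chain ending in an amine or a hydroxyl group, would bear on that question, and how far a longer unsubstituted chain would move the number also stays open.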